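Adding trifluoromethoxy to compound 3

The compounds below may be only part of what the source reports. "The series", "measured", "known", "first", "only" and "open" are said of these compounds alone.

Three compounds built on a shared core have so far been taken into a functional assay on NALM-6 cells (Homo sapiens) for cytotoxicity, read by luminescence and CellTiter-Glo, with a stated time of 3 days (a higher number here means a weaker inhibitor, a lower number a stronger inhibitor), and only one of them has yielded a number. Compound 3 `O=C(Nc1ccccc1)c1cc(F)ccc1O` stands without a single value on this scale, its entry reading "not determined" (no result reported) with no result behind it. Compound 1 `N#Cc1cccc(NC(=O)c2cc(F)ccc2O)c1` is in the same position, with "not determined" (no result reported) as its entry. Compound 2 `O=C(Nc1ccc(OC(F)(F)F)cc1)c1cc(F)ccc1O` alone gives a figure, and compound 2 comes in at 1210 nM in this measurement.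

Compound 4 `O=C(Nc1cccc(OC(F)(F)F)c1)c1cc(F)ccc1O` has yet to be measured. The structural change leading to it is trifluoromethoxy in place of hydrogen on an aromatic carbon and it places trifluoromethoxy in place of hydrogen on an aromatic carbon, meta to a large group. Among the measured compounds shown here, with no number for compound 3, there is no starting value against which to size this change in this assay and no measured step to serve as a guide. The only figure to lean on is that of compound 2 at 1210 nM and compound 4 is expected to land near it, with no gap beyond the usual scatter in either direction. The estimate for compound 4 is 1200 nM with 400 nM to 3600 nM as its expected range.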

Compound 4, half-maximal inhibitory concentration: 1370 nM
For compound 4 the middle estimate is 1.1-fold (0.06 log units) below the measured one, and the stated range covers the measured number.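

In this assay, among the compounds shown here, compound 4 gives 1370 nM, but compound 3 has no single number, so no step from compound 3 to compound 4 can be read. The compounds shown leave open how trifluoromethoxy in place of hydrogen shifts the value on this scale. No supporting evidence bears on this result.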